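The source may hold more compounds than are shown below. What is called first, only, known or untested is meant among the compounds shown, and "the series" means these compounds.

Compound 1: `Cc1ccccc1CN1CC=C(CCC(=O)NO)C1=O`, 2500 nM in a functional assay on NCI-H23 cells (Homo sapiens) for inhibition, read by sulforhodamine B assay; a lower number here means a stronger inhibitor of growth, a higher number a weaker inhibitor of growth. Compound 2: `Cc1ccc(CN2CC=C(CCC(=O)NO)C2=O)cc1`, 2500 nM. Compound 3: `O=C(CCC1=CCN(CCCCc2ccc(Cl)cc2)C1=O)NO`, 6250 nM.

In this assay compound 2 stands level with compound 1 at the digits shown, the two together giving the lowest numbers of the three, while compound 3 gives a higher number that lies beyond the usual scatter. The unmeasured compound 4 is `CC(C)(C)c1ccc(CN2CC=C(CCC(=O)NO)C2=O)cc1`. It differs from compound 2 in one place: tert-butyl in place of methyl on an aromatic carbon. Among the measured compounds shown here, no measured pair shows what this change does here. A small step is expected, not clearly beyond the scatter in either direction. Compound 4 is therefore estimated to give 2000 nM, in a range from 800 nM to 5000 nM. The expected step is a 1.3-fold lower number from compound 2 to compound 4 (0.10 log units; within the scatter).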

Compound 4, concentration for 50% growth inhibition: 420 nM
Compound 4: middle estimate off by 4.8-fold (0.68 log units), on the high side; the whole stated range lies above it.
By their numbers in this assay, from the lowest: compound 4; then compounds 1 and 2 (each within the scatter of the next); then compound 3.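

In this assay, tert-butyl in place of methyl on this aromatic carbon gives a 6.0-fold lower number from compound 2 to compound 4 (0.77 log units; beyond the scatter), a step beyond the scatter. The number thus responds to the group at this carbon, and a group of four carbon atoms is accepted here with a gain in growth inhibition. Nothing measured here accounts for this step.

As far as these compounds go, whether ethyl or isopropyl would give a step of intermediate size remains open. So does whether a similarly sized group containing other atoms, such as trifluoromethyl or a dimethylamino group, would match tert-butyl.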